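The source may report more compounds than this note shows. Statements on the series, on what has been measured and on what is new or still open speak of the compounds shown alone.

Measured so far in this series:
compound 1 `c1ccc(CNCC2CCN(CCCc3c[nH]c4ccc(-n5cnnc5)cc34)CC2)cc1`: 5.6 nM
compound 2 `c1ccc(C2CCCCN2C2CCN(CCCc3c[nH]c4ccc(-n5cnnc5)cc34)CC2)cc1`: 4.7 nM
compound 3 `OC[C@H](NC1CCN(CCCc2c[nH]c3ccc(-n4ccnc4)cc23)CC1)c1ccccc1`: 0.8 nM

In an assay on CHO cells for agonist activity at 5-hydroxytryptamine receptor 1D (Homo sapiens), read by GTPgammaS binding (a higher number here means that more compound is needed for the effect, a lower number that less compound is needed), compound 1 gives the highest of the three numbers. Compound 2 sits within the scatter of compound 1, so the two cannot be ordered. Compound 3 lies clearly below compound 1, beyond the scatter; of the three it is the only one in which the amine on the saturated ring carbon carries a hydroxyl and a benzene ring within a single substituent, with no intervening methylene to the ring.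

Compound 4 `O[C@@H]1Cc2ccccc2[C@H]1NC1CCN(CCCc2c[nH]c3ccc(-n4cnnc4)cc23)CC1` is not yet measured. Relative to compound 1 the change is (2-hydroxy-2,3-dihydro-1H-inden-1-yl)amino in place of (benzylamino)methyl on a saturated ring carbon. No pair of measured compounds covers this change directly, so its size is not known from a shown step. The new substituent resembles that of compound 3 in placing a hydroxyl and a benzene ring on an amine bound directly to the saturated ring carbon, and compound 3 gives 0.8 nM. On that basis the step in this assay is expected to run toward a lower number, beyond the scatter, with an expected 3.7-fold lower number from compound 1 to compound 4 (0.57 log units; beyond the scatter). Compound 4 is therefore estimated at 1.5 nM, with a range from 0.5 nM to 5 nM.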

Compound 4, half-maximal effective concentration: 13 nM
Compound 4: the middle estimate sits 8.7-fold (0.94 log units) below what was measured; measured number outside the range, above it.
By their numbers in this assay, from the lowest: compound 3; then compounds 2 and 1 (each within the scatter of the next); then compound 4.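

In this assay, (2-hydroxy-2,3-dihydro-1H-inden-1-yl)amino in place of (benzylamino)methyl on a saturated ring carbon gives a 2.3-fold higher number from compound 1 to compound 4 (0.37 log units; beyond the scatter), the first step measured at this position, and a modest one. A hydroxyl and a benzene ring on an amine bound directly to the saturated ring carbon therefore do not by themselves bring a lower number here, and compound 3, which differs from compound 4 in more than one place, cannot be read as showing the effect of that arrangement alone. No measurement shown bears on the reason for this step.

On these data alone, it remains open how much of the step belongs to the hydroxyl and how much to the two defined stereocentres, a question that a plain 2,3-dihydro-1H-inden-1-ylamino group, a methoxy group in place of the hydroxyl, or the opposite stereoisomer could help to separate. Also open is whether the low number of compound 3 belongs to its open-chain substituent or to its other ring at the far end of the molecule, since no pair shown differs in either feature alone.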